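Benzyl in place of the aminohydroxypropyl chain on the shared core

The source may report more compounds than this note shows. Statements on the series, on what has been measured and on what is new or still open speak of the compounds shown alone.

In a functional assay (B cells) with Mus musculus as the target (a lower number here means that less compound is needed, a higher number that more compound is needed for the effect), compound 2 `NCC(O)Cn1c(=O)n(C2OC(CO)[C@@H](O)[C@H]2O)c2nc(N)nc(O)c21` gives 28 uM, the lowest of the two numbers at hand; its nearest neighbour, compound 1 `COc1ccc(Cn2c(=O)n(C3OC(CO)[C@@H](O)[C@H]3O)c3nc(N)nc(O)c32)cc1`, gives 135 uM. The step of a 4.8-fold lower number from compound 1 to compound 2 (0.68 log units; beyond the scatter) is the only one measured so far and is the one that bears on the change now considered, since it concerns the same place on the shared core.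

Compound 3 `Nc1nc(O)c2c(n1)n(C1OC(CO)[C@@H](O)[C@H]1O)c(=O)n2Cc1ccccc1` has not yet been measured in this assay. It differs from compound 2 by phenyl in place of 2-amino-1-hydroxyethyl on a saturated chain carbon bound to an aromatic nitrogen.

This change runs in the opposite sense to the measured step: an aromatic ring returns where the 2-amino-1-hydroxyethyl group stood, though without the methoxy of compound 1. Because the step of a 4.8-fold lower number from compound 1 to compound 2 (0.68 log units; beyond the scatter) lowered the number when the ring left, a move back toward a higher number is expected for compound 3, of a size near that step, though its exact extent is uncertain since compound 3 lacks the methoxy.

The expected step is a 3.6-fold higher number from compound 2 to compound 3 (0.55 log units; beyond the scatter). Compound 3 is therefore estimated at 100 uM, within a range from 40 uM to 250 uM.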

Compound 3, concentration for half-maximal effect: 6 uM
Compound 3: the middle estimate sits 17-fold (1.22 log units) above what was measured; the measured number lies below the stated range.
By their numbers in this assay, from the lowest: compound 3; then compound 2; then compound 1.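

In this assay, the step of a 4.7-fold lower number from compound 2 to compound 3 (0.67 log units; beyond the scatter) shows that the 3-amino-2-hydroxypropyl chain is not what gives compound 2 its lower number, since benzyl in the same place, on a saturated chain carbon bound to an aromatic nitrogen, gives the lowest number of the three compounds. For the compounds shown here, the earlier compounds could not show this: their only step set the chain against a ring carrying methoxy, so the ring and its substituent could not be told apart, whereas the step of a 23-fold lower number from compound 1 to compound 3 (1.35 log units; beyond the scatter), hydrogen in place of methoxy on an aromatic carbon, now separates them and shows that the methoxy alone accounts for a large change in the number. The data offered here give no measured reason for either step.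

The compounds shown leave open whether the effect of the methoxy is particular to that group or would also appear with fluorine, chlorine or a methyl on the same aromatic carbon. They also leave open how the number would respond to a longer chain between the phenyl and the aromatic nitrogen, such as phenethyl in place of benzyl.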